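The source may hold more compounds than are shown below. What is called first, only, known or untested is meant among the compounds shown, and "the series" means these compounds.

Measured compounds:
- compound 1, `COc1cc(C2=NOC(CO[C@@H]3O[C@H](CSc4ncn[nH]4)[C@H]4OC5(CCCC5)O[C@@H]34)C2)cc(OC)c1OC`: 55000 nM
- compound 2, `CC1(C)O[C@H]2[C@H](OCc3noc(-c4ccc([N+](=O)[O-])cc4)n3)O[C@H](CO)[C@H]2O1`: > 100000 nM
- compound 3, `Cc1ccc(S(=O)(=O)OC[C@H]2O[C@@H](OCc3noc(-c4ccc([N+](=O)[O-])cc4)n3)[C@@H]3OC4(CCCC4)O[C@@H]32)cc1`: > 100000 nM

Among the compounds with values here, in a functional assay on T47D cells (Homo sapiens) for antiproliferative activity, read by sulforhodamine B assay, with a stated time of 48 h (on this read-out lower numbers stand for stronger inhibition of growth and higher numbers for weaker inhibition of growth), compound 1 gives 55000 nM, the only numeric value in the set. For compound 2 this assay reports only a limit, > 100000 nM. For compound 3 it likewise reports only a limit, > 100000 nM. Within the data shown here, compound 3 thus stands at the limit of > 100000 nM in this assay, at which 2 of the 3 values shown sit, and no measured step in this assay is available; what the set shows is weak growth inhibition throughout.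

Compound 4, `Nc1nnc(SC[C@H]2O[C@@H](OCc3noc(-c4ccc([N+](=O)[O-])cc4)n3)[C@@H]3OC4(CCCC4)O[C@@H]32)s1`, differs from compound 3 by (5-amino-1,3,4-thiadiazol-2-yl)sulfanyl in place of ((4-methylphenyl)sulfonyl)oxy on a saturated chain carbon bound to a saturated ring carbon. With compound 3 resting at a limit, the direction of the step can only be guessed from compound 1, which carries a sulfanyl-linked heteroaromatic group on the same kind of scaffold and reaches a measurable though weak value. The step from compound 3 to compound 4 is expected to be small, an at least 1.4-fold lower number from compound 3 to compound 4 (0.15 log units; that floor lies within the scatter), with the chance of falling back to the limit remaining high. For compound 4 the expected value in this assay is 70000 nM, within 25000 nM to 150000 nM.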

Compound 4, concentration for 50% growth inhibition: 19000 nM
Compound 4: the middle estimate sits 3.7-fold (0.57 log units) above what was measured, outside the stated range (below it).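

In this assay, the position on a saturated chain carbon bound to a saturated ring carbon turns out to respond to substitution: (5-amino-1,3,4-thiadiazol-2-yl)sulfanyl in place of ((4-methylphenyl)sulfonyl)oxy gives an at least 5.2-fold lower number from compound 3 to compound 4 (0.72 log units; beyond the scatter). From the compounds shown here alone, compound 3 carries only a limit, > 100000 nM, so the printed step is a floor and its true size remains unknown. The change brings compound 4 to a numeric value, clear of the limit: the limit of > 100000 nM in this assay, at which 2 of the 4 values shown sit.

The compounds shown do not separate the contribution of the amino group from that of the thiadiazole ring or the sulfanyl link. Going by these compounds, how a carboxylic acid or a simple alkylamine at this position would read in this assay also remains open.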